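Shortening the selenium arm on the shared core

The compounds below may be only part of what the source reports. "The series", "measured", "known", "first", "only" and "open" are said of these compounds alone.

Measured so far:
Compound 1, `COc1ccc(N(C)c2nc(C)nc3ccccc23)cc1C(=O)NCC[Se]C#N`: 179 nM
Compound 2, `C[Se]c1ccc(N(C)c2nc(C3CC3)nc3ccccc23)cc1`: 32 nM
Compound 3, `Cc1nc(N(C)c2ccc([Se]C#N)c(F)c2)c2ccccc2n1`: 37 nM

The three compounds were tested in a functional assay on HepG2 cells (Homo sapiens) for inhibition, read by MTT assay, with a stated time of 48 h; on this read-out higher numbers stand for weaker inhibition and lower numbers for stronger inhibition. Compound 1 gives the highest number of the three. Its nearest neighbour on the scale is compound 3, whose value in this assay of 37 nM lies beyond the scatter below it, and compound 2, with 32 nM, lies further below still. In both of those compounds the selenium sits directly on an aromatic carbon, whereas compound 1 carries its selenium at the end of a longer chain.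

Compound 4, `COc1ccc(N(C)c2nc(C)nc3ccccc23)cc1[Se]C#N`, has not yet been measured. It differs from compound 1 at one place: a group of 3 heavy atoms (1 carbon, 1 nitrogen, 1 selenium; no ring) in place of a group of 8 heavy atoms (4 carbon, 2 nitrogen, 1 oxygen, 1 selenium; no ring), on an aromatic carbon. The group that enters is the same kind of aromatic selenocyanate found in compound 3, placed on the ring ortho to a methoxy group and meta to a large group.

Since compound 2 and compound 3 both give numbers well below compound 1, the step in this assay is expected to go toward stronger inhibition, and it is estimated to fall beyond the scatter: a 4.0-fold lower number from compound 1 to compound 4 (0.60 log units; beyond the scatter). Compound 4 is therefore estimated at 45 nM, with a range from 15 nM to 140 nM.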

Compound 4, half-maximal inhibitory concentration: 59 nM
Compound 4: middle estimate off by 1.3-fold (0.12 log units), on the low side, and the stated range covers the measured number.
By their numbers in this assay, from the lowest: compounds 2, 3 and 4 (each within the scatter of the next); then compound 1.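

In this assay, exchanging the longer selenium-bearing chain for a selenocyanate set directly on the aromatic carbon, ortho to a methoxy group and meta to a large group, gives a 3.0-fold lower number from compound 1 to compound 4 (0.48 log units; beyond the scatter), a modest change that can be read on a single core with nothing else altered. At this position, then, the chain with its carbonyl and amide hydrogen is not needed for inhibition on this read-out, and the smaller group, which keeps the selenium and the nitrile, gives the lower number. No measurement is available here that bears on what lies behind this step.

The amide and the chain length change together in this one step, so the compounds shown leave open whether either alone accounts for the difference, which a longer chain without the amide could address. They also leave open how a plain nitrile or a methylseleno group at this same place would compare with the selenocyanate on the core of compound 1.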